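Fluoro for hydrogen on the shared core: compound 4

The source may hold more compounds than are shown below. What is called first, only, known or untested is meant among the compounds shown, and "the series" means these compounds.

Three compounds have numbers in a functional assay on MCF7 cells (Homo sapiens) for antiproliferative activity; on this read-out higher numbers stand for weaker inhibition and lower numbers for stronger inhibition. Compound 1 `COc1cc(Cc2nc3c(N)nc(F)nc3n2CCOC(C)C)cc(OC)c1OC` gives 15800 nM. Compound 2 `COc1cc(Cc2nc3c(N)ncnc3n2CCOC(C)C)cc(OC)c1OC` gives 38900 nM. Compound 3 `COCCn1c(Cc2cc(OC)c(OC)c(OC)c2)nc2c(N)ncnc21` gives 64600 nM. Compound 4 `COCCn1c(Cc2cc(OC)c(OC)c(OC)c2)nc2c(N)nc(F)nc21` has not yet been measured in this assay.

Compound 1 and compound 2 differ by fluoro in place of hydrogen on an aromatic carbon. That change carried a 2.5-fold lower number from compound 2 to compound 1 (0.39 log units; beyond the scatter). Compound 2 and compound 3 differ by methyl in place of isopropyl on an oxygen on a saturated carbon, and that step reads a 1.7-fold higher number from compound 2 to compound 3 (0.22 log units; within the scatter), so the numbers of compound 2 and compound 3 are not separated here.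

Compound 4 relates to compound 3 as compound 1 relates to compound 2: the difference is fluoro in place of hydrogen on an aromatic carbon. The description of the place is the same word for word in both pairs, so this is the same change, made on a core that carries the methyl rather than the isopropyl on the side-chain oxygen. The change has been observed once only, and a single step is a thin basis.

Going by the values given here, with that caution, the step from compound 3 to compound 4 is expected to be a 2.5-fold lower number from compound 3 to compound 4 (0.40 log units; beyond the scatter), resting on the one observed step of a 2.5-fold lower number from compound 2 to compound 1 (0.39 log units; beyond the scatter) and carried across unchanged. The side-chain difference between compound 2 and compound 3 gave only a 1.7-fold higher number from compound 2 to compound 3 (0.22 log units; within the scatter), so the core of compound 3 is taken to behave like that of compound 2. Compound 4 is therefore estimated at 26000 nM in this assay, with a likely range from 12000 nM to 55000 nM.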

Compound 4, half-maximal inhibitory concentration: 64600 nM
Compound 4: middle estimate off by 2.5-fold (0.40 log units), on the low side; the whole stated range lies below it.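

On the core with methyl on the side-chain oxygen, fluoro in place of hydrogen gives no change at the digits printed from compound 3 to compound 4 (within the scatter) in this assay, while on the core with isopropyl it gave a 2.5-fold lower number from compound 2 to compound 1 (0.39 log units; beyond the scatter), and the two steps are not separated: the same change on two cores in this assay, a 2.5-fold lower number (0.39 log units; beyond the scatter) from compound 2 to compound 1 and no change at the digits printed (within the scatter) from compound 3 to compound 4, 2.5-fold (0.39 log units) apart, within the scatter of two such steps. The change from isopropyl to methyl on that oxygen reads a 4.1-fold higher number from compound 1 to compound 4 (0.61 log units; beyond the scatter) with fluoro on the core and a 1.7-fold higher number from compound 2 to compound 3 (0.22 log units; within the scatter) with hydrogen there, and these two steps are likewise not separated: the same change on two cores in this assay, a 1.7-fold higher number (0.22 log units; within the scatter) from compound 2 to compound 3 and a 4.1-fold higher number (0.61 log units; beyond the scatter) from compound 1 to compound 4, 2.5-fold (0.39 log units) apart, within the scatter of two such steps. The fluoro step therefore cannot be said to depend on the core, yet it is not shown to carry over either, since it lies beyond the scatter on one core and within it on the other, and a single pair per core cannot tell a real difference between cores from scatter.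

The compounds shown leave open how a chloro or a nitrile would read on the same aromatic carbon between two ring nitrogen atoms, on either core. They also leave open whether the fluoro step would hold with a longer chain or an amine in place of the ether side chain.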